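A few compounds are considered here, and "the series" means these few. Any claim that something is new, unique, unknown or untested is made for them only; others in the source may bear on it.

Measured in a functional assay on the whole organism for inhibition, with Mus musculus as the target; on this read-out higher numbers stand for an effect only at larger amounts of compound and lower numbers for an effect already at smaller amounts:
Compound 1, `CCN1CCCC1CNC(=O)c1cc(NS(=O)(=O)N(C)C)c(C)cc1OC`: 13.3 mg/kg
Compound 2, `CCN1CCCC1CNC(=O)c1cc(NS(=O)(=O)N(C)C)c(Cl)cc1OC`: 8.3 mg/kg
Compound 3, `CCN1CCCC1CNC(=O)c1cc(N(C)S(N)(=O)=O)c(C)cc1OC`: > 50 mg/kg, which is a limit of the assay and not a number

Compound 1 and compound 2 share one core and differ by a single change, (chloro in place of methyl on an aromatic carbon). The step of a 1.6-fold lower number from compound 1 to compound 2 (0.20 log units; within the scatter) is small. Compound 3 carries a different core, and the change from compound 1 is methyl(sulfamoyl)amino in place of (dimethylsulfamoyl)amino on an aromatic carbon. The step of an at least 3.7-fold higher number from compound 1 to compound 3 (0.57 log units; beyond the scatter) is the only one in this set that goes beyond the scatter. For compound 3 the result is a limit of the assay, (the limit of > 50 mg/kg in this assay, at which 1 of the 3 values shown sits).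

Compound 4, `CCN1CCCC1CNC(=O)c1cc(N(C)S(N)(=O)=O)c(Cl)cc1OC`, has not yet been measured in this assay. It differs from compound 3 by chloro in place of methyl on an aromatic carbon. This is the same kind of change as from compound 1 to compound 2, but the place is not identical: in compound 3 the carbon is ortho to a methyl(sulfamoyl)amino group, whereas in compound 1 it is ortho to a (dimethylsulfamoyl)amino group.

For the change at hand a step about as small as a 1.6-fold lower number from compound 1 to compound 2 (0.20 log units; within the scatter) is expected. The expected step is therefore a step that the limit leaves unreadable from compound 3 to compound 4. Since compound 3 gives only a limit, > 50 mg/kg, the estimate for compound 4 rests on that limit and may itself come back as a limit. For compound 4 the estimated value is 55 mg/kg, with an expected range from 25 mg/kg to 150 mg/kg.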

Compound 4, dose for half-maximal effect: > 50 mg/kg
Compound 4 ended at the assay's limit; the forecaster's own chance of this, stated with the estimate: 55%; the middle value lies beyond the limit too.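

In this assay compound 4 gives > 50 mg/kg, which is a limit of the assay and not a number. The step from compound 3 to compound 4 cannot be read, but methyl(sulfamoyl)amino in place of (dimethylsulfamoyl)amino on the chloro compounds gives an at least 6.0-fold higher number from compound 2 to compound 4 (0.77 log units; beyond the scatter), so the direction of this change carries over from the core of compound 1 to the core of compound 2, with the number going up beyond the scatter on both: the same change on two cores in this assay, an at least 3.7-fold higher number (0.57 log units; beyond the scatter) from compound 1 to compound 3 and an at least 6.0-fold higher number (0.77 log units; beyond the scatter) from compound 2 to compound 4; the limit leaves it open whether they differ This shows that the change moves the read-out the same way on these two cores, but it does not show that the size of the step carries over, because the upper end of both steps is hidden: the limit of > 50 mg/kg in this assay, at which 2 of the 4 values shown sit.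

The compounds shown leave open how far compound 3 and compound 4 lie past the limit, and so whether chloro in place of methyl makes any difference once the methyl(sulfamoyl)amino group is present. They also leave open how the series would read with an ethyl group or a longer chain on the sulfamoyl nitrogens, or with bromo or fluoro in place of the chloro.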